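The source may hold more compounds than are shown below. What is called first, only, known or untested is meant among the compounds shown, and "the series" means these compounds.

Measured compounds: compound 1 `CN1CCN(CCCCCn2c3c(c4ccccc42)C(=O)c2c[n+]([O-])c4ccccc4c2C3=O)CC1` gives 830 nM in a functional assay on SH-SY5Y cells (Homo sapiens) for cytotoxicity, read by MTT assay, with a stated time of 72 h; on this read-out higher numbers stand for weaker inhibition and lower numbers for stronger inhibition; compound 2 `O=C1c2c[n+]([O-])c3ccccc3c2C(=O)c2c1c1ccccc1n2Cc1cn([C@@H]2C[C@H](O)[C@@H](CO)O2)nn1` gives 150 nM; compound 3 `CN(C)CCCCn1c2c(c3ccccc31)C(=O)c1c[n+]([O-])c3ccccc3c1C2=O` gives 250 nM.

Compound 1 thus stands highest of the three numbers. Its nearest neighbour is compound 3, reached by the step of a 3.3-fold lower number from compound 1 to compound 3 (0.52 log units; beyond the scatter), which swaps the group at the end of the chain; compound 2 lies further off. Compound 4 `CN1CCN(CCCn2c3c(c4ccccc42)C(=O)c2c[n+]([O-])c4ccccc4c2C3=O)CC1` differs from compound 1 by 4-methylpiperazin-1-yl in place of 2-(4-methylpiperazin-1-yl)ethyl on a saturated chain carbon, three bonds along the chain from an aromatic nitrogen, that is, the chain is cut from 5-(4-methylpiperazin-1-yl)pentyl to 3-(4-methylpiperazin-1-yl)propyl with the end group kept. Among the measured compounds shown here, no measured step alters the chain in this way; the single step from compound 1 to compound 3 concerns the end group only. The expected step of a 1.2-fold lower number from compound 1 to compound 4 (0.07 log units; within the scatter) is therefore small, with no direction beyond the scatter, and compound 4 is estimated at 700 nM (range 300 nM to 1700 nM).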

Compound 4, half-maximal inhibitory concentration: 560 nM
Compound 4: middle estimate off by 1.3-fold (0.10 log units), on the high side; measured number inside the range.
By their numbers in this assay, from the lowest: compounds 2 and 3 (each within the scatter of the next); then compounds 4 and 1 (each within the scatter of the next).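

Cutting the chain from 5-(4-methylpiperazin-1-yl)pentyl to 3-(4-methylpiperazin-1-yl)propyl with the end group kept gives a 1.5-fold lower number from compound 1 to compound 4 (0.17 log units; within the scatter) and so gives the first reading of chain length at this position, a change that stays inside the scatter. The step of a 2.2-fold higher number from compound 3 to compound 4 (0.35 log units; beyond the scatter) stays beyond the scatter, but it alters chain and end group together and cannot be assigned to either. No measurement here offers an explanation for these numbers.

The compounds shown leave open how a morpholine or a primary amine would read at the chain end. They also leave open how dimethylamino would read on the propyl or pentyl chain.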